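Acetyl in place of ethyl on the aniline nitrogen

A few compounds are considered here, and "the series" means these few. Any claim that something is new, unique, unknown or untested is made for them only; others in the source may bear on it.

Working notes on the series. Compound 3 `CCN(CC(=O)N1CCC[C@H](c2ccccc2)[C@@H]1CN1CCCC1)c1ccc(Cl)c(Cl)c1` holds the lowest number of the three measured in an assay on HEK293 cells for displacement of a labelled ligand from Urotensin-2 receptor (Homo sapiens) (on this read-out lower numbers stand for stronger inhibition and higher numbers for weaker inhibition), where compound 3 gives 31.6 nM. Compound 1 `CN(CC(=O)N1CCCCC1CN1CCCC1)c1ccc(Cl)c(Cl)c1`, built on a different core, gives 398 nM in this assay, and compound 2 `Cc1ccc2scc(CCC(=O)N3CCC[C@H](c4ccccc4)[C@@H]3CN3CCCC3)c2c1` gives 3160 nM. Both gaps from compound 3 are beyond the scatter, so compound 3 is the strongest binder among the measured set. Among the measured compounds shown here, no two measured compounds differ in a single place, so no measured step is available to calibrate the next change. Compound 4 `CC(=O)N(CC(=O)N1CCC[C@H](c2ccccc2)[C@@H]1CN1CCCC1)c1ccc(Cl)c(Cl)c1` differs from compound 3 by acetyl in place of ethyl on a nitrogen on an aromatic ring. Among the measured compounds only alkyl groups, ethyl in compound 3 and methyl in compound 1, occupy that nitrogen; no measured compound carries an acyl group there, so the outlook rests on the structural change alone. The change is expected to weaken binding, with a 9.5-fold higher number from compound 3 to compound 4 (0.98 log units; beyond the scatter) as the estimated step, clearly beyond the scatter. Compound 4 is expected to give 300 nM in this assay, with a range from 60 nM to 2000 nM.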

Compound 4, inhibition constant: 1580 nM
Compound 4: the middle estimate sits 5.3-fold (0.72 log units) below what was measured; the range from low to high includes it.
By their numbers in this assay, from the lowest: compound 3; then compound 1; then compounds 4 and 2 (each within the scatter of the next).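

Acetyl in place of ethyl on a nitrogen on an aromatic ring gives a 50-fold higher number from compound 3 to compound 4 (1.70 log units; beyond the scatter) in this assay and is the first single-place step that can be read in the series. It shows that binding at this position is sensitive to the group on the nitrogen: the swap adds one oxygen, one double bond outside aromatic rings and one hydrogen-bond acceptor, and the step is large and beyond the scatter. Nothing on hand ties the loss to any one of these features.

Still open, from the compounds shown here alone, is whether a longer alkyl chain, a 2-hydroxyethyl group or a plain hydrogen on this nitrogen would keep binding close to that of compound 3. Also open, going by these compounds, is whether acetyl in place of methyl on the core of compound 1 would carry a step of similar size.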